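This account rests on a few compounds, and the source may have more. Where it says the series, first, only, none or still open, it means among the compounds named here.

Compound 1 `CCOC(=O)c1c(-c2cc3ccc(OC)cc3oc2=O)nn(-c2cccc(C)c2)c1C(=O)OCC` gives 171000 nM in a functional assay on A549 cells (Homo sapiens) for cytotoxicity, read by MTT assay, with a stated time of 48 h; a lower number here means a stronger inhibitor, a higher number a weaker inhibitor.
Compound 2 `CCOC(=O)c1c(-c2cc3ccc(OCC=C(C)C)cc3oc2=O)nn(-c2ccccc2)c1C(=O)OCC` gives 136000 nM in this assay.

Of these two numbers, compound 2 has the lower one, but its gap to compound 1 lies within the scatter, so the two compounds cannot be placed in order. Compound 3 `CCOC(=O)c1c(-c2cc3ccc(OCC=C(C)C)cc3oc2=O)nn(-c2cccc(C)c2)c1C(=O)OCC` has not yet been measured. It differs from compound 2 by methyl in place of hydrogen on an aromatic carbon. Nothing measured here shows what this change does, so no step beyond the scatter is expected in either direction. Compound 3 is expected to give 140000 nM in this assay, with a range from 70000 nM to 280000 nM. The expected step is a 1.0-fold higher number from compound 2 to compound 3 (0.01 log units; within the scatter), within the scatter.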

Compound 3, half-maximal inhibitory concentration: 178000 nM
For compound 3 the middle estimate is 1.3-fold (0.10 log units) below the measured one; the measured number falls inside the stated range.
By their numbers in this assay, from the lowest: compounds 2, 1 and 3 (each within the scatter of the next).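

For the compounds shown here, compound 3 gives the first reading of methyl in place of hydrogen on this aromatic ring: this assay shows a 1.3-fold higher number from compound 2 to compound 3 (0.12 log units; within the scatter) and so does not separate phenyl from 3-methylphenyl. With the methyl present, 2-methylprop-1-en-1-yl in place of hydrogen on the chain carbon gives a 1.0-fold higher number from compound 1 to compound 3 (0.02 log units; within the scatter) and likewise changes nothing that can be read. No measurement here offers an explanation for either result. Still open, going by these compounds, is whether a different group at this ring carbon, such as an amine or a carboxylic acid, would move the number beyond the scatter.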